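Swapping hydroxy for ethyl in a cytotoxic series

The source may report more compounds than this note shows. Statements on the series, on what has been measured and on what is new or still open speak of the compounds shown alone.

Compound 1 `COC1=C(C)C(=O)/C(=C(O)/C=C/c2cccc(OC)c2)C(=O)C1(C)C`: 3.3 ug/mL
Compound 2 `COC1=C(C)C(=O)/C(=C(O)/C=C/c2ccc(O)cc2)C(=O)C1(C)C`: 3.8 ug/mL

In a functional assay on KB cells (Homo sapiens) for cytotoxicity (a higher number here means that more compound is needed for the effect, a lower number that less compound is needed), compound 2 gives 3.8 ug/mL, which lies within the scatter of compound 1 at 3.3 ug/mL. Among the compounds with values here, with only these two numbers, compound 2 stands level with its sole neighbour.

Compound 3 `CCc1ccc(/C=C/C(O)=C2/C(=O)C(C)=C(OC)C(C)(C)C2=O)cc1` differs from compound 2 at one place: ethyl in place of hydroxy on an aromatic carbon. The change turns 4-hydroxyphenyl into 4-ethylphenyl.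

Within the data shown here, only one measured step bears on this change. The step of a 1.2-fold higher number from compound 1 to compound 2 (0.06 log units; within the scatter) also alters the aromatic end of the molecule, and it stays within the scatter. Among the measured compounds shown here, no measured pair exchanges hydroxy for ethyl, so this is a weak guide.

The step expected in this assay is therefore a 1.1-fold lower number from compound 2 to compound 3 (0.04 log units; within the scatter), none beyond the scatter. Compound 3 is estimated at 3.5 ug/mL, with an expected range from 1.5 ug/mL to 8 ug/mL.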

Compound 3, concentration for half-maximal effect: 6.9 ug/mL
The estimate for compound 3 lay 2.0-fold (0.29 log units) below the measured number, and the stated range covers the measured number.
By their numbers in this assay, from the lowest: compounds 1, 2 and 3 (each within the scatter of the next, the first and the last beyond it).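

In this assay the exchange of hydroxy for ethyl on the aromatic carbon gives a 1.8-fold higher number from compound 2 to compound 3 (0.26 log units; within the scatter) and so does not separate the two compounds, even though a group with hydrogen-bond donor and acceptor counts of one each gives way to one with none. The 4-ethylphenyl group does, however, yield the first modest separation in this set, with a 2.1-fold higher number from compound 1 to compound 3 (0.32 log units; beyond the scatter) when it stands in place of 3-methoxyphenyl. Nothing available explains either step.

From the compounds shown here alone, whether the shift seen with ethyl would continue with a longer chain such as butyl remains open. Going by these compounds, it is equally open how an amine or a carboxylic acid at this same position would compare, and whether any group here could bring the number down beyond the scatter.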